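Swapping the Amine on a Chromone Thiocarbamate

The source may hold more compounds than are shown below. What is called first, only, known or untested is meant among the compounds shown, and "the series" means these compounds.

Measured so far:
compound 1 `O=c1c(CSC(=S)N2CCOCC2)coc2cc(Cl)ccc12`: 900 nM
compound 2 `O=c1c(CSC(=S)N2CCOCC2)coc2ccccc12`: 4400 nM

Both were tested in a functional assay on HEp-2 cells (Homo sapiens) for antiproliferative activity, read by MTT assay, with a stated time of 72 h; on this read-out higher numbers stand for weaker inhibition and lower numbers for stronger inhibition. In this assay, going by the values given here, compound 1 gives the lower of the two numbers, and the single step seen, a 4.9-fold higher number from compound 1 to compound 2 (0.69 log units; beyond the scatter), comes from hydrogen in place of chloro on an aromatic carbon. Compound 3 `CC(C)N(C(=S)SCc1coc2cc(Cl)ccc2c1=O)C(C)C` has not yet been measured. It differs from compound 1 by diisopropylamino in place of morpholin-4-yl on a thiocarbonyl carbon. Among the compounds with values here, no measured step touches this part of the structure: the one step available concerns the aromatic chloro and says nothing about the amine on the thiocarbonyl carbon. With nothing to lean on, the step expected for compound 3 is no change at the digits printed from compound 1 to compound 3 (within the scatter), one kept within the scatter, though the range must be wide. Compound 3 is therefore estimated at 900 nM, between 250 nM and 3500 nM.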

Compound 3, half-maximal inhibitory concentration: 4200 nM
Beside the measured number, compound 3's estimate is 4.7-fold (0.67 log units) below it, outside the stated range (above it).
By their numbers in this assay, from the lowest: compound 1; then compounds 3 and 2 (each within the scatter of the next).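

Diisopropylamino in place of morpholin-4-yl on the thiocarbonyl carbon gives a 4.7-fold higher number from compound 1 to compound 3 (0.67 log units; beyond the scatter) in this assay and so shows that the amine at this position affects the result, just as the aromatic chloro does. The change is not a single one: the entering group has no ring and no hydrogen-bond acceptors, so the ring and the ring oxygen of morpholin-4-yl leave together, and this one step cannot separate their shares. Nothing measured here gives a reason for the step.

Piperidin-1-yl would keep the ring without the oxygen, and dimethylamino would show an open amine with no isopropyl groups, so how either compares with compound 1 remains open. Also open, as far as these compounds go, is whether diisopropylamino behaves the same way on the core without chloro.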